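The compounds below may be only part of what the source reports. "The series", "measured", "known", "first", "only" and "open" are said of these compounds alone.

The measured compounds:
compound 1, `C/C(=C\c1cc(-c2ccc(C)nc2)co1)C(N)=O`, in a functional assay on A549 cells (Homo sapiens) for cytotoxicity, read by CCK-8 assay, with a stated time of 24 h (on this read-out lower numbers stand for stronger inhibition and higher numbers for weaker inhibition), compound 1 gives > 50000 nM, which is a limit of the assay.
compound 2, `C/C(=C\c1cc(-c2ccc(F)nc2)co1)C(N)=O`, in this assay compound 2 gives > 50000 nM, again a limit.
compound 3, `C/C(=C\c1cc(-c2ccc(C)cc2)cs1)C(N)=O`, in this assay compound 3 gives > 50000 nM, again a limit.

All three values sit at the limit of > 50000 nM in this assay, at which 3 of the 3 values shown sit. Compound 2 differs from compound 1 by fluoro in place of methyl on an aromatic carbon, and the resulting step, a step that the two limits leave unreadable from compound 1 to compound 2, cannot be sized because both ends are limits. Compound 4, `C/C(=C\c1cc(-c2ccc(F)cc2)cs1)C(N)=O`, has not yet been measured; it differs from compound 3 by fluoro in place of methyl on an aromatic carbon. This is the same kind of change as that from compound 1 to compound 2, though the surroundings differ: in compound 1 the methyl sits on a six-membered aromatic ring with one nitrogen, next to the ring nitrogen, whereas in compound 3 it sits on a six-membered aromatic ring of carbon only. How the core of compound 3 differs from that of compound 1 is not broken down here.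

Because a step that the two limits leave unreadable from compound 1 to compound 2 is unreadable and every value shown rests at the limit of > 50000 nM in this assay, at which 3 of the 3 values shown sit, the step that the limit leaves unreadable from compound 3 to compound 4 is expected to be small and unreadable as well. Compound 4 is therefore estimated at 100000 nM, within 30000 nM to 400000 nM, most likely reported only as a limit.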

Compound 4, half-maximal inhibitory concentration: > 50000 nM
Compound 4: a limit, no number; the forecaster's own chance of this, stated with the estimate: 85%; the middle value does not contradict the limit.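

In this assay compound 4 gives > 50000 nM, which is a limit of the assay. Compound 3 also rests at a limit, so no step can be read from compound 3 to compound 4: the limit of > 50000 nM in this assay, at which 4 of the 4 values shown sit.

The compounds shown leave open how fluoro and methyl compare in this series, since none of them gives a readable value.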